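Swapping 2-Nitrophenyl for 4-Methoxyphenyl: An Expected Step

The source may hold more compounds than are shown below. What is called first, only, known or untested is meant among the compounds shown, and "the series" means these compounds.

Three compounds have been measured in a functional assay for inhibition, tested at 20 ug/mL; a lower number here means a weaker effect, a higher number a stronger effect of the compound at the concentration tested:
compound 1 `Cc1cc(O)c(C(C)C)cc1-c1cc(-c2ccccc2[N+](=O)[O-])c(C#N)c(=O)[nH]1`, 20%
compound 2 `COc1ccc(-c2cc(-c3cc(C(C)C)c(O)cc3C)[nH]c(=O)c2C#N)c(OC)c1`, 27%
compound 3 `COc1ccc(-c2cc(-c3cc(C(C)C)c(O)cc3C)[nH]c(=O)c2C#N)cc1OC`, 25%

The three numbers sit close together: the steps of a number 7 percentage points higher from compound 1 to compound 2 (within the scatter) and a number 5 percentage points higher from compound 1 to compound 3 (within the scatter) both fall within the scatter, so compound 1 cannot be separated from the other two on the numbers shown. Compound 4 `COc1ccc(-c2cc(-c3cc(C(C)C)c(O)cc3C)[nH]c(=O)c2C#N)cc1` differs from compound 1 by 4-methoxyphenyl in place of 2-nitrophenyl on an aromatic carbon. The two measured steps that bear on this exchange, a number 7 percentage points higher from compound 1 to compound 2 (within the scatter) and a number 5 percentage points higher from compound 1 to compound 3 (within the scatter), each replaced 2-nitrophenyl with a dimethoxyphenyl and each stayed within the scatter, as did a number 2 percentage points lower from compound 2 to compound 3 (within the scatter). A step no larger than the scatter is therefore expected in this assay, in either direction. Compound 4 is estimated at 24%, with a range from 12% to 36%, which means an expected step of a number 4 percentage points higher from compound 1 to compound 4 (within the scatter).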

Compound 4, a percentage reported as inhibition, at one concentration (the size of the read-out at that concentration, not a potency): 24%
Compound 4: middle estimate and measured number agree at the digits printed; the range from low to high includes it.
By their numbers in this assay, from the lowest: compounds 1, 4, 3 and 2 (each within the scatter of the next).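

In this assay, a single 4-methoxyphenyl on this carbon, opposite the ring nitrogen, cannot be separated from 2-nitrophenyl (a number 4 percentage points higher from compound 1 to compound 4 (within the scatter)). Hydrogen in place of either methoxy also leaves the reading within the scatter (a number 1 percentage points lower from compound 3 to compound 4 (within the scatter); a number 3 percentage points lower from compound 2 to compound 4 (within the scatter)), so neither second methoxy shows a measurable contribution here. No measurement is available that explains this flat response. Every group shown here is a substituted phenyl. As far as these compounds go, whether an amine, a carboxylic acid or a longer alkyl chain at this position would move the reading beyond the scatter remains open.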